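This account rests on a few compounds, and the source may have more. Where it says the series, first, only, none or still open, it means among the compounds named here.

Values measured in an ADME assay on HEp-2 cells (Homo sapiens) for cytotoxicity; a lower number here means that less compound is tolerated, a higher number that more compound is tolerated:

- compound 1 `C=C(C)n1c(=O)n(Cc2nc3ccccc3n2CCC(C)C)c2ccccc21`: 24600 nM
- compound 2 `CC(C)CCn1c(Cn2c(=O)n(C(C)C)c3ccccc32)nc2c(CO)cccc21`: 22000 nM
- compound 3 `COCc1cccc2c1nc(Cn1c(=O)n(C(C)C)c3ccccc31)n2CCC(C)C`: 26700 nM

Compound 1 stands among these three values and lies within the scatter of both compound 2 and compound 3, so it holds no distinct rank. The next compound to be measured is compound 4 `C=C(C)n1c(=O)n(Cc2nc3cc(C#N)ccc3n2CCC(C)C)c2ccccc21`, which differs from compound 1 by cyano in place of hydrogen on an aromatic carbon. In short, this is cyano in place of hydrogen on an aromatic carbon.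

Among the measured compounds shown here, the one measured step between closely matched compounds is a 1.2-fold higher number from compound 2 to compound 3 (0.08 log units; within the scatter). It concerns a different change, methyl in place of hydrogen on an oxygen on a saturated carbon, so it bears on the new change only indirectly. For the measured compounds named here, no compound with a cyano group has been measured. The small spread of the series therefore gives no reason to expect a shift beyond the scatter in this assay, and no direction can be favoured. The expected change is a 1.1-fold lower number from compound 1 to compound 4 (0.03 log units; within the scatter). For compound 4 the estimate is 23000 nM, with an expected range from 9000 nM to 55000 nM.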

Compound 4, half-maximal cytotoxic concentration: 1480 nM
Compound 4: middle estimate off by 16-fold (1.19 log units), on the high side, outside the stated range (below it).
By their numbers in this assay, from the lowest: compound 4; then compounds 2, 1 and 3 (each within the scatter of the next).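

In this assay, cyano in place of hydrogen on an aromatic carbon gives a 17-fold lower number from compound 1 to compound 4 (1.22 log units; beyond the scatter), the only step shown that lies beyond the scatter. Among the compounds shown here, the three earlier compounds all lie within the scatter of one another, so they gave no sign that a single change could move this number so far. This carbon, on a six-membered aromatic ring of carbon only, is thus the first place in the series where a change leaves markedly less compound tolerated, although nothing available accounts for the drop.

As far as these compounds go, whether the drop belongs to cyano itself or would also follow from another group here, such as fluorine, methoxy or an amine, remains open. From the compounds shown here alone, it is also open whether cyano on another carbon of this ring would give a similar number.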